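Lengthening the thioether chain by one carbon

This account rests on a few compounds, and the source may have more. Where it says the series, first, only, none or still open, it means among the compounds named here.

Compound 1 `CCCCCCSC[C@H](NC(C)=O)C(=O)CCl`: 3300 nM
Compound 2 `CCCCCCCCCCCSC[C@H](NC(C)=O)C(=O)CCl`: 1700 nM

In a functional assay on NALM-6 cells (Homo sapiens) (on this read-out lower numbers stand for stronger inhibition and higher numbers for weaker inhibition), compound 2 gives the lower of the two numbers, but the gap to compound 1 stays within the scatter, as the step of a 1.9-fold lower number from compound 1 to compound 2 (0.29 log units; within the scatter) shows. Compound 3 `CCCCCCCCCCCCSC[C@H](NC(C)=O)C(=O)CCl` differs from compound 2 by methyl in place of hydrogen on a saturated chain carbon, ten or more bonds along the chain from a sulfur. Among the compounds with values here, the only step that bears on this change is that from compound 1 to compound 2, which added a far larger piece of chain for a difference still within the scatter; one more carbon is therefore expected to move the number little, if at all. Compound 3 is expected at about 1400 nM, between 600 nM and 3500 nM, an estimated step of a 1.2-fold lower number from compound 2 to compound 3 (0.08 log units; within the scatter).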

Compound 3, half-maximal inhibitory concentration: 2000 nM
The estimate for compound 3 lay 1.4-fold (0.15 log units) below the measured number; measured number inside the range.
By their numbers in this assay, from the lowest: compounds 2, 3 and 1 (each within the scatter of the next).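

In this assay the methyl added on a saturated chain carbon gives a 1.2-fold higher number from compound 2 to compound 3 (0.07 log units; within the scatter) and the full extension of the chain gives a 1.7-fold lower number from compound 1 to compound 3 (0.22 log units; within the scatter). All three compounds therefore remain within the scatter of one another, so this extension of the chain does not separate them on this read-out. No evidence available here bears on this result.

Going by these compounds, whether a longer chain, or an amine or a carboxylic acid at the end of the chain, would move the number beyond the scatter remains open.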